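A few compounds are considered here, and "the series" means these few. Any claim that something is new, unique, unknown or untested is made for them only; others in the source may bear on it.

In a functional assay on A549 cells (Homo sapiens) for inhibition, read by sulforhodamine B assay, with a stated time of 72 h (on this read-out higher numbers stand for weaker inhibition and lower numbers for stronger inhibition), compound 1 (`COc1cc2c(Nc3ccc(F)c(Cl)c3)ncnc2cc1OCCOCCn1ccnc1[N+](=O)[O-]`) gives 7640 nM, compound 2 (`COc1cc2c(Nc3cccc(Br)c3)ncnc2cc1OCCCCn1ccnc1[N+](=O)[O-]`) gives 1970 nM, and compound 3 (`COc1cc2c(Nc3cccc(Br)c3)ncnc2cc1OCCCCCn1ccnc1[N+](=O)[O-]`) gives 8420 nM. Compound 3 lies within the scatter of compound 1, while the gap to compound 2 is beyond it: a 4.3-fold higher number from compound 2 to compound 3 (0.63 log units; beyond the scatter), a modest step.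

Compound 4 (`COc1cc2c(Nc3cccc(Br)c3)ncnc2cc1OCCOCCn1ccnc1[N+](=O)[O-]`) differs from compound 3 in one place: 2-(2-nitro-1H-imidazol-1-yl)ethoxy in place of 3-(2-nitro-1H-imidazol-1-yl)propyl on a saturated chain carbon, two bonds along the chain from an oxygen on an aromatic ring. It carries 2-(2-nitro-1H-imidazol-1-yl)ethoxy in place of 3-(2-nitro-1H-imidazol-1-yl)propyl on a saturated chain carbon, two bonds along the chain from an oxygen on an aromatic ring.

For the measured compounds named here, no measured step covers this exact change. Going by the values given here, the one step available, a 4.3-fold higher number from compound 2 to compound 3 (0.63 log units; beyond the scatter), bears on it only loosely, since it lengthens the chain instead. The closer guide is compound 1, which has the same chain as compound 4 and differs from it elsewhere. Compound 1 gives 7640 nM. In this assay, the expected outcome is therefore no change beyond the scatter, with an estimated 1.2-fold lower number from compound 3 to compound 4 (0.08 log units; within the scatter). Compound 4 is expected at about 7000 nM, within an estimated range of 3000 nM to 16000 nM.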

Compound 4, half-maximal inhibitory concentration: 10100 nM
The estimate for compound 4 lay 1.4-fold (0.16 log units) below the measured number; the range from low to high includes it.
By their numbers in this assay, from the lowest: compound 2; then compounds 1, 3 and 4 (each within the scatter of the next).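

In this assay, putting 2-(2-nitro-1H-imidazol-1-yl)ethoxy in place of 3-(2-nitro-1H-imidazol-1-yl)propyl gives a 1.2-fold higher number from compound 3 to compound 4 (0.08 log units; within the scatter), so at this place the two groups, of equal heavy-atom count, cannot be told apart. The step of a 5.1-fold higher number from compound 2 to compound 4 (0.71 log units; beyond the scatter), with 2-(2-nitro-1H-imidazol-1-yl)ethoxy in place of 2-(2-nitro-1H-imidazol-1-yl)ethyl, shows that this group, like 3-(2-nitro-1H-imidazol-1-yl)propyl, stands apart from the 2-(2-nitro-1H-imidazol-1-yl)ethyl group. The first read on the other site of change, 3-bromophenyl in place of 3-chloro-4-fluorophenyl on a nitrogen on an aromatic ring, gives a 1.3-fold higher number from compound 1 to compound 4 (0.12 log units; within the scatter), and so shows no difference there with this chain.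

Nothing available explains why these numbers fall as they do. The compounds shown leave open whether an amine in place of the chain oxygen would match these values, and how 3-chloro-4-fluorophenyl would read with the 2-(2-nitro-1H-imidazol-1-yl)ethyl group.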